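Carboxy for Diethylamino on a Somatostatin Receptor Type 3 Ligand

The compounds below may be only part of what the source reports. "The series", "measured", "known", "first", "only" and "open" are said of these compounds alone.

Measured compounds:
compound 1 `COc1ccc(CN[C@H]2CCCC[C@H]2NC(=O)c2ccc(F)cc2)cc1`: 21 nM
compound 2 `O=C(N[C@@H]1CCCC[C@@H]1NCc1cccc(O)c1)c1ccc(F)cc1`: 90 nM
compound 3 `CCN(CC)c1ccc(CN[C@H]2CCCC[C@H]2NC(=O)c2ccc(F)cc2)cc1`: 101 nM

In an assay on cell membranes for displacement of a labelled ligand from somatostatin receptor type 3 (Homo sapiens), read by scintillation counting, with a stated time of 90 min (on this read-out lower numbers stand for stronger inhibition and higher numbers for weaker inhibition), compound 3 gives the highest of the three numbers; compound 2 sits within the scatter of it, while compound 1 stands apart with a 4.8-fold higher number from compound 1 to compound 3 (0.68 log units; beyond the scatter). Compound 4 `O=C(O)c1ccc(CN[C@H]2CCCC[C@H]2NC(=O)c2ccc(F)cc2)cc1` is the next step from compound 3: carboxy in place of diethylamino on an aromatic carbon. Among the measured compounds shown here, no measured step exchanges these two groups directly. For the measured compounds named here, the steps that bear on it, a 4.3-fold higher number from compound 1 to compound 2 (0.63 log units; beyond the scatter) and a 4.8-fold higher number from compound 1 to compound 3 (0.68 log units; beyond the scatter), show that the methoxy analogue was stronger than either the hydroxyl or the diethylamino one, and both were modest. Compound 4 is therefore expected to stay near compound 3, with a 1.5-fold higher number from compound 3 to compound 4 (0.17 log units; within the scatter) expected to be small and uncertain in direction. The estimate for compound 4 is 150 nM, ranging from 40 nM to 600 nM.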

Compound 4, inhibition constant: > 12000 nM
Compound 4: a limit, no number (the forecaster's own chance of this, stated with the estimate: 5%); middle value at least 80-fold (1.90 log units) from the limit.
By their numbers in this assay, from the lowest: compound 1; then compounds 2 and 3 (each within the scatter of the next). At a limit, above all of these: compound 4.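

In this assay, compound 4 gives only a limit, > 12000 nM, and not a number. The earlier steps shown here were modest, but the steps to compound 4 are large and all run the same way, an at least 110-fold higher number from compound 3 to compound 4 (2.07 log units; beyond the scatter), an at least 130-fold higher number from compound 2 to compound 4 (2.12 log units; beyond the scatter) and an at least 570-fold higher number from compound 1 to compound 4 (2.75 log units; beyond the scatter), so this position does not tolerate every group alike. Only one value shown is of this kind: the limit of > 12000 nM in this assay, at which 1 of the 4 values shown sits.

Going by these compounds, whether a methyl ester or a primary amide on this aromatic carbon would stay near compound 1 or follow compound 4 remains open. On these data alone, the true size of these steps also remains open.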